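Adding a methyl to the amide nitrogen of compound 3

The compounds below may be only part of what the source reports. "The series", "measured", "known", "first", "only" and "open" are said of these compounds alone.

Of the compounds shown here, three sharing one core have been measured in an assay on isolated protein for displacement of a labelled ligand from Adrenergic receptor alpha-1 (Rattus norvegicus); a higher number here means a weaker inhibitor, a lower number a stronger inhibitor. Compound 1 `COc1cc2nc(N3CCC(C(=O)NC4CCCC4)CC3)nc(N)c2cc1OC` gives 0.63 nM. Compound 2 `COc1cc2nc(N3CCC(C(=O)Nc4ccccc4)CC3)nc(N)c2cc1OC` gives 0.47 nM, and compound 3 `COc1cc2nc(N3CCC(C(=O)NCc4ccccc4)CC3)nc(N)c2cc1OC` gives 0.22 nM. Compound 3 stands lowest of the three: the step of a 2.1-fold lower number from compound 2 to compound 3 (0.33 log units; beyond the scatter) and the step of a 2.9-fold lower number from compound 1 to compound 3 (0.46 log units; beyond the scatter) both lie beyond the scatter, while a 1.3-fold lower number from compound 1 to compound 2 (0.13 log units; within the scatter) does not.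

Compound 4 `COc1cc2nc(N3CCC(C(=O)N(C)Cc4ccccc4)CC3)nc(N)c2cc1OC` keeps the benzyl group of compound 3 and differs only in methyl in place of hydrogen on an amide-type nitrogen. Going by the values given here, none of the measured steps touches this kind of change; all three swap the group carried by the amide nitrogen, and none replaces the amide hydrogen itself. There is therefore no direct guide in this set, and the expectation rests on the general observation that such a small change often moves the number little. Compound 4 is estimated at 0.35 nM, within 0.12 nM to 1.1 nM, which means an expected step of a 1.6-fold higher number from compound 3 to compound 4 (0.20 log units; within the scatter), likely not beyond the scatter.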

Compound 4, inhibition constant: 0.2 nM
The estimate for compound 4 lay 1.8-fold (0.24 log units) above the measured number; low and high end bracket the measured number.
By their numbers in this assay, from the lowest: compounds 4 and 3 (each within the scatter of the next); then compounds 2 and 1 (each within the scatter of the next).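

In this assay, with methyl in place of hydrogen on the amide-type nitrogen, the result is a 1.1-fold lower number from compound 3 to compound 4 (0.04 log units; within the scatter) and so the amide hydrogen of compound 3 can be replaced by methyl with the two numbers staying within the scatter of each other. The lower numbers of the benzyl-bearing compound 3 also carry over to its methylated form, with a 2.4-fold lower number from compound 2 to compound 4 (0.37 log units; beyond the scatter) and a 3.2-fold lower number from compound 1 to compound 4 (0.50 log units; beyond the scatter) both printed as beyond the scatter. No measured evidence shown here gives a reason for these results.

As far as these compounds go, whether an ethyl group or a longer chain on this nitrogen would leave the number equally unmoved stays open. So does whether methyl on the amide nitrogen of compound 1 or compound 2 would behave as it does on compound 3.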